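The source may hold more compounds than are shown below. What is called first, only, known or untested is meant among the compounds shown, and "the series" means these compounds.

Compound 1 `Cc1ccc(S(=O)(=O)N[C@@H](CC(=O)NC(C)(C)C)C(=O)NCCNC(=O)c2ccccc2Cl)cc1`: > 11000 nM, a limit
Compound 2 `Cc1ccc(S(=O)(=O)N[C@@H](CC(=O)NC(C)(C)C)C(=O)NCCNC(=O)c2cc(Cl)ccc2Cl)cc1`: > 11000 nM, a limit

In an ADME assay on HepG2 cells (Homo sapiens) for cytotoxicity (a higher number here means that more compound is needed for the effect, a lower number that less compound is needed), compound 2 gives > 11000 nM, which is a limit of the assay and not a number. Among the compounds with values here, its standing is shared with the only other measured compound: the limit of > 11000 nM in this assay, at which 2 of the 2 values shown sit.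

The next analogue is compound 3 `Cc1ccc(S(=O)(=O)N[C@@H](CC(=O)NC(C)(C)C)C(=O)NCCNC(=O)c2cc(C)ccc2F)cc1`, which keeps the shared core and changes only the aryl group of the benzamide: 2-fluoro-5-methylphenyl in place of 2,5-dichlorophenyl on a carbonyl carbon. Put in words, 2-fluoro-5-methylphenyl stands in place of 2,5-dichlorophenyl on a carbonyl carbon.

Within the data shown here, one measured step bears on this, a step that the two limits leave unreadable from compound 1 to compound 2, where chloro replaces hydrogen on an aromatic carbon. Among the measured compounds shown here, it gives no size to carry over, and the series holds no measured step on fluoro or methyl groups. The expectation therefore rests on compound 2 at > 11000 nM, and compound 3 is expected to be reported as a limit as well.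

In this assay the expected outcome is a number no higher from compound 2 to compound 3 (the limit leaves the size open), with no step beyond the scatter expected.

For compound 3 the estimate is 11000 nM, expected to lie between 6000 nM and 20000 nM.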

Compound 3, half-maximal effective concentration: > 11000 nM
Compound 3: a limit, no number; the forecaster's own chance of this, stated with the estimate: 85%; the middle value lies on the limit itself.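

In this assay compound 3 gives > 11000 nM, a limit of the assay and not a number. The steps from compound 1 and from compound 2 to compound 3 therefore cannot be read. The compounds shown leave open what half-maximal effective concentration any of them gives, and whether the aryl group of the benzamide alters it.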